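The source may report more compounds than this note shows. Statements on the series, on what has been measured and on what is new or still open speak of the compounds shown alone.

Measured so far in an ADME assay on MRC5 cells (Homo sapiens), read by MTT assay, with a stated time of 72 h; on this read-out higher numbers stand for weaker inhibition and lower numbers for stronger inhibition:
compound 1, `COc1nc(N)nc2c1c(-c1ccco1)cn2[C@@H]1O[C@H](CO)[C@@H](O)[C@H]1O`, 89700 nM
compound 2, `Nc1nc(N)c2c(-c3cc4ccccc4o3)cn([C@@H]3O[C@H](CO)[C@@H](O)[C@H]3O)c2n1`, 78500 nM

Compound 2 gives the lowest of these two numbers, with compound 1 the nearest, and the gap between them lies within the usual scatter, so neither can be called the weaker or the stronger. Compound 3, `Nc1nc(N)c2c(-c3ccco3)cn([C@@H]3O[C@H](CO)[C@@H](O)[C@H]3O)c2n1`, has not yet been measured. It differs from compound 2 in one place: furan-2-yl in place of 1-benzofuran-2-yl on an aromatic carbon. Going by the values given here, no measured pair shares this change, so there is no measured step to lean on. A small step is expected, if anything toward a slightly higher number, giving a 1.2-fold higher number from compound 2 to compound 3 (0.08 log units; within the scatter) in this assay. Compound 3 is therefore estimated at 95000 nM, expected to fall between 40000 nM and 200000 nM.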

Compound 3, half-maximal inhibitory concentration: > 100000 nM
Compound 3 was reported as a limit; the forecaster's own chance of this, stated with the estimate: 30%; middle value at least 1.0-fold (0.02 log units) away from the limit.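

In this assay compound 3 gives > 100000 nM, which is a limit and not a number. Furan-2-yl in place of 1-benzofuran-2-yl gives an at least 1.2-fold higher number from compound 2 to compound 3 (0.10 log units; that floor lies within the scatter), and amino in place of methoxy gives an at least 1.1-fold higher number from compound 1 to compound 3 (0.04 log units; that floor lies within the scatter), so neither change is shown to lower the number. The true size of both steps stays hidden because the reading of compound 3 stops at a limit: the limit of > 100000 nM in this assay, at which 1 of the 3 values shown sits.

Still open, as far as these compounds go, is how a phenyl ring or a simple amine on this aromatic carbon would read. A carboxylic acid there is equally untested among the compounds shown.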